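The source may report more compounds than this note shows. Statements on the series, on what has been measured and on what is new or still open speak of the compounds shown alone.

In a functional assay on MGC-803 cells (Homo sapiens) for inhibition, read by sulforhodamine B assay (on this read-out higher numbers stand for weaker inhibition and lower numbers for stronger inhibition), two compounds with the same core have been measured, and they differ only in the amine group attached to it. Compound 1 `O=C1C=C(N2CCC2)C(=O)c2c1nc1n2[C@H]2OC[C@@H](O)[C@H]2OC1` gives > 16000 nM, which is a limit and not a number. Compound 2 `O=C1C=C(NC2CCCCC2)C(=O)c2c1nc1n2[C@H]2OC[C@@H](O)[C@H]2OC1` gives > 8000 nM, which is also a limit. Compound 2 therefore has no measured potency of its own, and it stands only as a limit beside another limit.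

Compound 3 `CCOc1ccc(NC2=CC(=O)c3nc4n(c3C2=O)[C@H]2OC[C@@H](O)[C@H]2OC4)cc1` keeps the core and the amine nitrogen of compound 2 but carries 4-ethoxyphenyl in place of cyclohexyl on that nitrogen: 4-ethoxyphenyl in place of cyclohexyl on an amine nitrogen. Within the data shown here, only one measured step bears on this change, a step that the two limits leave unreadable from compound 1 to compound 2, and it has no readable size. Neither measured compound carries an aromatic ring in this place. Among the measured compounds shown here, with that step as the only guide, no size can be carried over, so no shift beyond the scatter is expected in either direction, and weak inhibition is expected to persist. The estimate amounts to a number no higher from compound 2 to compound 3 (the limit leaves the size open). For compound 3 the expected value is 8000 nM, with an estimated range from 2000 nM to 30000 nM.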

Compound 3, half-maximal inhibitory concentration: 1110 nM
Estimate against measurement, compound 3: 7.2-fold (0.86 log units) above, outside the stated range (below it).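

In this assay, the group on this amine nitrogen makes a readable difference: 4-ethoxyphenyl in place of cyclohexyl gives an at least 7.2-fold lower number from compound 2 to compound 3 (0.85 log units; beyond the scatter), whereas the only other step shown cannot be read. Among these compounds, compound 3 is the only one of the three compounds with a measured number, 1110 nM, and the only one with an aromatic ring in this place. The true size of the step remains open, because compound 2 stands at a limit and not at a number: the limit of > 8000 nM in this assay, at which 1 of the 3 values shown sits.

The change from cyclohexyl to 4-ethoxyphenyl brings in both an aromatic ring and an ethoxy group, so the compounds shown do not tell whether the ring alone accounts for the step or the ethoxy group also contributes. Plain phenyl would bear on that question, while 4-methoxyphenyl, 4-aminophenyl or benzyl would show how far the step depends on the ethoxy chain, on the group carried by the ring, or on the ring standing directly on the nitrogen.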